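The source may report more compounds than this note shows. Statements on the series, on what has been measured and on what is new or still open speak of the compounds shown alone.

Compounds measured in a functional assay on MKN-45 cells (Homo sapiens) for cytotoxicity, read by MTT assay, with a stated time of 72 h; on this read-out lower numbers stand for stronger inhibition and higher numbers for weaker inhibition:
compound 1 `COc1ccc(Nc2cc(Nc3ccc(Oc4ccncc4-c4cccnc4)c(F)c3)ncn2)cc1` gives 1010 nM
compound 2 `Fc1cc(Nc2cc(Nc3ccc(Cl)cc3)ncn2)ccc1Oc1ccncc1-c1cccnc1` gives 240 nM
compound 3 `Fc1cc(Nc2cc(Nc3cccc(Cl)c3)ncn2)ccc1Oc1ccncc1-c1cccnc1` gives 30 nM

Compound 3 stands lowest of the three, with an 8.0-fold lower number from compound 2 to compound 3 (0.90 log units; beyond the scatter) and a 34-fold lower number from compound 1 to compound 3 (1.53 log units; beyond the scatter). Compound 4 `Fc1ccc(Nc2cc(Nc3ccc(Oc4ccncc4-c4cccnc4)c(F)c3)ncn2)cc1` differs from compound 3 in one place: 4-fluorophenyl in place of 3-chlorophenyl on a nitrogen on an aromatic ring. The most relevant step runs in the other direction on the same ring, an 8.0-fold lower number from compound 2 to compound 3 (0.90 log units; beyond the scatter), while a 4.2-fold lower number from compound 1 to compound 2 (0.62 log units; beyond the scatter) shows how much the group at that position of the ring can matter. Among the measured compounds shown here, no measured pair sets fluoro against chloro. Compound 4 is therefore expected to fall back toward compound 2, and the step of a 10-fold higher number from compound 3 to compound 4 (1.00 log units; beyond the scatter) is expected to be modest and upward. The estimate for compound 4 is 300 nM, within 100 nM to 900 nM.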

Compound 4, half-maximal inhibitory concentration: 160 nM
Estimate against measurement, compound 4: 1.9-fold (0.27 log units) above; the range from low to high includes it.
By their numbers in this assay, from the lowest: compound 3; then compounds 4 and 2 (each within the scatter of the next); then compound 1.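

The step of a 1.5-fold lower number from compound 2 to compound 4 (0.18 log units; within the scatter) gives the first pair setting fluoro against chloro, and it shows no difference that stands out from the scatter. Compound 4 still falls short of 3-chlorophenyl, with a 5.3-fold higher number from compound 3 to compound 4 (0.73 log units; beyond the scatter) on this nitrogen, while a 6.3-fold lower number from compound 1 to compound 4 (0.80 log units; beyond the scatter) places fluoro ahead of methoxy. No measurement at hand explains these steps. The compounds shown leave open whether the edge of 3-chlorophenyl comes from the chloro itself or from where it sits on the ring. They also leave open what an amine or a carboxylic acid on that ring would give.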